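The compounds below may be only part of what the source reports. "The series", "measured", "known", "first", "only" and "open" are said of these compounds alone.

Working notes on the series. The shared core is that of compound 2 `COc1cccc(/C=N/NC(=O)CSc2nnc(-c3ccncc3)o2)c1`; only the aryl group on the carbon with a double bond to nitrogen varies. In a functional assay on BGC-823 cells (Homo sapiens) for cytotoxicity, read by MTT assay, with a stated time of 48 h (on this read-out lower numbers stand for stronger inhibition and higher numbers for weaker inhibition), compound 2 gives 15800 nM, while compound 1 `O=C(CSc1nnc(-c2ccncc2)o1)N/N=C/c1ccc([N+](=O)[O-])cc1` gives 31500 nM. Among the measured compounds shown here, compound 2 thus carries the lower of the two numbers, but the single measured step, a 2.0-fold lower number from compound 1 to compound 2 (0.30 log units; within the scatter), does not support any ranking of the two.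

Compound 3 `O=C(CSc1nnc(-c2ccncc2)o1)N/N=C/c1ccc(O)c(O)c1` has not been measured in this assay. Its change from compound 2: 3,4-dihydroxyphenyl in place of 3-methoxyphenyl on a carbon with a double bond to nitrogen. For the measured compounds named here, the only measured step at this position stayed within the scatter, and nothing measured bears directly on the entering group, so no basis exists for predicting a move beyond the scatter in either direction. The expected step is therefore a 1.1-fold lower number from compound 2 to compound 3 (0.05 log units; within the scatter), with no direction favoured. Compound 3 is estimated at 14000 nM, in a range from 5000 nM to 40000 nM.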

Compound 3, half-maximal inhibitory concentration: 1260 nM
For compound 3 the middle estimate is 11-fold (1.05 log units) above the measured one; the whole stated range lies above it.
By their numbers in this assay, from the lowest: compound 3; then compounds 2 and 1 (each within the scatter of the next).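

In this assay the aryl group on the carbon with a double bond to nitrogen proves able to move the read-out well beyond the scatter, which the earlier pair did not show. With 3,4-dihydroxyphenyl entering, the change from 3-methoxyphenyl gives a 13-fold lower number from compound 2 to compound 3 (1.10 log units; beyond the scatter) and the change from 4-nitrophenyl gives a 25-fold lower number from compound 1 to compound 3 (1.40 log units; beyond the scatter) so compound 3 stands apart from both other compounds. Nothing available accounts for the size of these steps.

The compounds shown leave open whether both hydroxy groups are needed or one is enough, a question that a 4-hydroxyphenyl or a 3-hydroxyphenyl group on the same carbon would address. They also leave open whether a 3,4-dimethoxyphenyl or a 3,4-diaminophenyl group would keep a number as low as that of compound 3.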